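Shifting the Methoxy Group on the Aryl Ring

The source may hold more compounds than are shown below. What is called first, only, known or untested is meant among the compounds shown, and "the series" means these compounds.

Compound 1 `COc1cccc(-n2cc(COC(=O)/C(C)=C/CC/C(C)=C/CC/C(C)=C/CC[C@@H]3[C@@]4(C)CCC(=O)C(C)(C)[C@H]4CC[C@@]3(C)O)nn2)c1`: > 150000 nM
Compound 2 `C/C(=C\CC/C(C)=C/CC[C@@H]1[C@@]2(C)CCC(=O)C(C)(C)[C@H]2CC[C@@]1(C)O)CC/C=C(\C)C(=O)OCc1cn([C@@H]2C[C@@H](n3cc(C)c(=O)[nH]c3=O)O[C@H]2CO)nn1`: 35000 nM

Both compounds were tested in a functional assay on A549 cells (Homo sapiens) for antiproliferative activity, read by MTT assay, with a stated time of 48 h; a lower number here means a stronger inhibitor, a higher number a weaker inhibitor. For compound 1 the number shown is a limit of the assay, not a measured value (the limit of > 150000 nM in this assay, at which 1 of the 2 values shown sits). Compound 2 gives 35000 nM in this assay.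

Compound 3 `COc1ccc(-n2cc(COC(=O)/C(C)=C/CC/C(C)=C/CC/C(C)=C/CC[C@@H]3[C@@]4(C)CCC(=O)C(C)(C)[C@H]4CC[C@@]3(C)O)nn2)cc1` has not yet been measured. It differs from compound 1 in one place (4-methoxyphenyl in place of 3-methoxyphenyl on an aromatic nitrogen). For the measured compounds named here, no measured pair shows the effect of such a change, so a step of no size beyond the usual scatter is expected, a number no higher from compound 1 to compound 3 (the limit leaves the size open). Compound 3 is therefore estimated at 150000 nM, between 50000 nM and 400000 nM, most likely again reported only as a limit.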

Compound 3, half-maximal inhibitory concentration: > 150000 nM
Compound 3: a limit, no number; the forecaster's own chance of this, stated with the estimate: 70%; the middle value lies on the limit itself.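

Compound 1 and compound 3 both stand at a limit of the assay, not at a measured number, so no step between them can be read: the limit of > 150000 nM in this assay, at which 2 of the 3 values shown sit.

The compounds shown leave open whether 3-methoxyphenyl and 4-methoxyphenyl differ at all in strength.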